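This account rests on a few compounds, and the source may have more. Where it says the series, first, only, none or still open, it means among the compounds named here.

Two compounds of the series have numbers in a functional assay on Huh-7 cells (Homo sapiens) for antiproliferative activity, read by sulforhodamine B assay, with a stated time of 72 h (on this read-out higher numbers stand for weaker inhibition and lower numbers for stronger inhibition), so far. Compound 1 `Cc1ccccc1COc1ccc(-c2cc(CN3CCN(Cc4ccc(C(F)(F)F)cc4)CC3)no2)cc1` gives 1200 nM. Compound 2 `Cc1cccc(COc2ccc(-c3cc(CN4CCN(Cc5ccc(C(F)(F)F)cc5)CC4)no3)cc2)c1` gives 5000 nM, the higher of the two numbers; the step of a 4.2-fold higher number from compound 1 to compound 2 (0.62 log units; beyond the scatter) is modest but beyond the scatter. Compound 3 `Cc1ccc(COc2ccc(-c3cc(CN4CCN(Cc5ccc(C(F)(F)F)cc5)CC4)no3)cc2)cc1` differs from compound 2 by 4-methylphenyl in place of 3-methylphenyl on a saturated chain carbon bound to an oxygen on an aromatic ring. Among the compounds with values here, no measured step covers this exact change; the only related step, a 4.2-fold higher number from compound 1 to compound 2 (0.62 log units; beyond the scatter), shows that shifting the methyl on this phenyl moves the number modestly. For compound 3 a step of a 1.3-fold lower number from compound 2 to compound 3 (0.10 log units; within the scatter) is therefore expected, with no firm direction. Compound 3 is estimated at 4000 nM, within 1500 nM to 12000 nM.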

Compound 3, half-maximal inhibitory concentration: 1500 nM
Compound 3: middle estimate off by 2.7-fold (0.43 log units), on the high side, within the range that was stated.
By their numbers in this assay, from the lowest: compounds 1 and 3 (each within the scatter of the next); then compound 2.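

In this assay the effect of moving the methyl on this phenyl is now seen from a second side: 4-methylphenyl in place of 3-methylphenyl gives a 3.3-fold lower number from compound 2 to compound 3 (0.52 log units; beyond the scatter) and 4-methylphenyl in place of 2-methylphenyl gives a 1.3-fold higher number from compound 1 to compound 3 (0.10 log units; within the scatter) in the same series. Among these three groups only 3-methylphenyl stands apart, while compound 1 and compound 3 lie within the scatter of each other. No evidence at hand accounts for this difference. Still open, from the compounds shown here alone, is how an unsubstituted phenyl, or a chlorine or methoxy group in place of the methyl, would read at this position.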